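Amide aryl variation on the shared core: compound 3 outlook

The source may report more compounds than this note shows. Statements on the series, on what has been measured and on what is new or still open speak of the compounds shown alone.

Measured so far:
compound 1 `O=C(Nc1cccc(-c2oc3cc(-c4ccc(F)cc4)ccc3c(=O)c2O)c1)c1ccc(F)cc1` — 9280 nM
compound 2 `O=C(Nc1cccc(-c2oc3cc(-c4ccc(F)cc4)ccc3c(=O)c2O)c1)c1cccc(F)c1` — 15500 nM

Among the measured compounds shown here, in a functional assay on HepG2 cells (Homo sapiens) for antiproliferative activity, read by CCK-8 assay, with a stated time of 72 h (on this read-out lower numbers stand for stronger inhibition and higher numbers for weaker inhibition), compound 2 stands with the highest number of the two, the nearest being compound 1, though the only step available, a 1.7-fold higher number from compound 1 to compound 2 (0.22 log units; within the scatter), lies within the scatter. Compound 3 `Cc1cc(C)cc(C(=O)Nc2cccc(-c3oc4cc(-c5ccc(F)cc5)ccc4c(=O)c3O)c2)c1` differs from compound 2 by 3,5-dimethylphenyl in place of 3-fluorophenyl on a carbonyl carbon. For the measured compounds named here, the single measured step concerns this same carbonyl position and gave no change beyond the scatter, so no step beyond the scatter is expected for a 1.1-fold lower number from compound 2 to compound 3 (0.04 log units; within the scatter) either. Compound 3 is therefore estimated at 14000 nM, with a range of 5000 nM to 40000 nM.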

Compound 3, half-maximal inhibitory concentration: 13400 nM
Beside the measured number, compound 3's estimate is 1.0-fold (0.02 log units) above it; the range from low to high includes it.
By their numbers in this assay, from the lowest: compounds 1, 3 and 2 (each within the scatter of the next).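

In this assay the steps of a 1.2-fold lower number from compound 2 to compound 3 (0.06 log units; within the scatter) and a 1.4-fold higher number from compound 1 to compound 3 (0.16 log units; within the scatter) show that the scatter also covers a change of substituent at this carbonyl carbon, not only the shift between 4-fluorophenyl and 3-fluorophenyl. An aryl ring without fluorine, 3,5-dimethylphenyl, reads the same as both fluorophenyl amides. No data are available to account for this flat result.

Still open, going by these compounds, is whether a carboxylic acid, an amine or a saturated alkyl chain in place of the aryl ring would move the number beyond the scatter. Changes on the shared core also remain open.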